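The source may report more compounds than this note shows. Statements on the series, on what has been measured and on what is new or still open speak of the compounds shown alone.

Measured compounds in a functional assay on MCF7 cells (Homo sapiens) for cytotoxicity, read by MTT assay, with a stated time of 24 h, tested at 80 ug/mL; a higher number here means a stronger effect of the compound at the concentration tested, a lower number a weaker effect:

Compound 1, `CN1CCN(CC(=O)Nc2ccc(-c3nc(-c4ccccc4)c(-c4ccccc4)n3C)cc2)CC1`, gives 50.3%.
Compound 2, `CCN1CCN(CC(=O)Nc2ccc(-c3nc(-c4ccccc4)c(-c4ccccc4)n3C)cc2)CC1`, gives 46.3%.
Compound 3, `Cn1c(-c2ccc(NC(=O)CN3CCN(c4ccccc4)CC3)cc2)nc(-c2ccccc2)c1-c1ccccc1`, gives 72.5%.

Of these three, compound 3 stands highest: its value lies beyond the scatter above both compound 1 and compound 2, which are within the scatter of each other. The two steps leading to compound 3 are a number 22.2 percentage points higher from compound 1 to compound 3 (beyond the scatter) and a number 26.2 percentage points higher from compound 2 to compound 3 (beyond the scatter); both show that an aromatic ring on the ring nitrogen goes with a stronger effect than a small alkyl group there, while a number 4 percentage points lower from compound 1 to compound 2 (within the scatter) shows that switching between those two small alkyl groups changes little.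

Compound 4, `Cn1c(-c2ccc(NC(=O)CN3CCN(Cc4ccccc4)CC3)cc2)nc(-c2ccccc2)c1-c1ccccc1`, differs from compound 3 in one place: benzyl in place of phenyl on an amine nitrogen in a ring. The aromatic ring is kept but set one saturated carbon further from the ring nitrogen. Among the measured compounds shown here, no measured step covers this exact change. Because a number 22.2 percentage points higher from compound 1 to compound 3 (beyond the scatter) shows that the gain to compound 3, which sits highest, came with the aromatic ring on the ring nitrogen, the ring in compound 4 is expected to hold most of that effect, with a small drop possible as the group moves toward the shape of the alkyl cases.

For compound 4 the expected step is a number 9.5 percentage points lower from compound 3 to compound 4 (within the scatter).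

Compound 4 is therefore estimated at 63%, within a range from 46% to 80%.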

Compound 4, a percentage reported as activity, at one concentration (the size of the read-out at that concentration, not a potency): 49.5%
Compound 4: middle estimate off by 13.5 percentage points, on the high side; the measured number falls inside the stated range.
By their numbers in this assay, from the lowest: compounds 2, 4 and 1 (each within the scatter of the next); then compound 3.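

In this assay, among the compounds shown here, the earlier compounds showed only that phenyl on the ring nitrogen outdid a small alkyl group there, and the new result shows that having an aromatic ring in the group is not enough: benzyl in place of phenyl gives a number 23 percentage points lower from compound 3 to compound 4 (beyond the scatter) at this position. Compound 4 also cannot be told apart from the two small alkyl compounds, with a number 3.2 percentage points higher from compound 2 to compound 4 (within the scatter) and a number 0.8 percentage points lower from compound 1 to compound 4 (within the scatter) on the same scale. Among these four compounds, then, the stronger effect belongs to phenyl set directly on the ring nitrogen, and the one extra saturated carbon of benzyl goes with the loss of that gain, so the aromatic ring counts only when it is attached directly.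

Nothing measured here gives a reason for this loss. From the compounds shown here alone, it also remains open whether a longer chain ending in phenyl, such as phenethyl, would behave like benzyl, and whether a phenyl ring carrying a chlorine or a methoxy group would keep, raise or lower the effect seen with compound 3.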